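Compound 1 and a chain with one double bond

The source may hold more compounds than are shown below. What is called first, only, known or untested is meant among the compounds shown, and "the series" means these compounds.

In an ADME assay on microsomes from liver (Homo sapiens) for metabolic stability, using NADPH, with a stated time of 10 min (a higher number here means that more of the compound is left, a lower number that less of the compound is left), compound 1 (`NCCCCN(C[C@H]1Cc2ncccc2CN1)[C@H]1CCCc2cccnc21`) gives 100% and compound 2 (`NCCCCN(C[C@@H]1Cc2ncccc2CN1)[C@H]1CCCc2cccnc21`) gives 98% while compound 3 (`NCCCCN(C[C@H]1Cc2cccnc2CN1)[C@H]1CCCc2cccnc21`) stands at 96% on the same read-out. All three numbers lie within the scatter of one another, which leaves compound 1 level with the other two and close to the top of the scale.

Compound 4 (`NC/C=C\CN(C[C@H]1Cc2ncccc2CN1)[C@H]1CCCc2cccnc21`) keeps the core of compound 1 and alters only the chain, where the change reads 3-aminoprop-1-en-1-yl in place of 3-aminopropyl on a saturated chain carbon bound to an amine nitrogen in full. Cut one bond further out, the same difference is 4-aminobutyl to 4-aminobut-2-en-1-yl.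

For the measured compounds named here, one measured step bears on this, and only loosely: a number 2 percentage points lower from compound 1 to compound 2 (within the scatter) is small, and it comes with the fact that compounds 1 and 2 differ only in the configuration as drawn as the sole difference. Going by the values given here, no measured step touches the chain itself, and the double bond that enters remains untested. In this assay no step beyond the scatter is expected, although the numbers sit so near the top of the scale that any real movement could only be downward. The estimated step is a number 6 percentage points lower from compound 1 to compound 4 (within the scatter) on this reasoning. Compound 4 is expected at an estimated 94% within a range of 80% to 100% (an estimate, not a measurement).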

Compound 4, percent of the compound remaining: 85%
For compound 4 the middle estimate is 9 percentage points above the measured one; the measured number falls inside the stated range.
By their numbers in this assay, from the lowest: compound 4; then compounds 3, 2 and 1 (each within the scatter of the next).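

The chain proves to be a place where this assay responds: the double bond of 3-aminoprop-1-en-1-yl, in place of 3-aminopropyl on a saturated chain carbon bound to an amine nitrogen, brings a number 15 percentage points lower from compound 1 to compound 4 (beyond the scatter) and so moves the read-out away from the top of the scale. Both groups hold the same count of heavy atoms and neither carries a ring, so what separates compound 1 from compound 4 at this position is the double bond and not the size of the chain. For the compounds shown here, the one other measured single-place step, a change of configuration on a saturated ring carbon, stayed within the scatter, but it says nothing about the chain, and what is at hand offers no cause for the new step.

From the compounds shown here alone, how an alkyne in the chain, or a longer chain ending in the same primary amine, would behave in this assay remains open. Also open, going by these compounds, is whether the same double bond would bring a step of like size on the cores of compound 2 and compound 3.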